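Swapping the amine on a nitro-sulfone WNK1 inhibitor

This account rests on a few compounds, and the source may have more. Where it says the series, first, only, none or still open, it means among the compounds named here.

Within the data shown here, compound 1 `O=[N+]([O-])c1cc(S(=O)(=O)C(Cl)(Cl)Br)ccc1NC1CCCCC1` is the only compound here with a numeric reading: in an assay on cells for inhibition of serine/threonine-protein kinase WNK1 (Homo sapiens), read by luminescence and Kinase-Glo, with a stated time of 2 h (a higher number here means a weaker inhibitor, a lower number a stronger inhibitor), compound 1 gives 4000 nM. Compound 2 `O=[N+]([O-])c1cc(S(=O)(=O)C(Cl)Cl)ccc1NC1CCCCC1` differs only at the carbon bearing the sulfonyl group; in this assay compound 2 gives > 1000000 nM, which is a limit of the assay rather than a number (the limit of > 1000000 nM in this assay, at which 1 of the 2 values shown sits). Among the measured compounds shown here, the step of an at least 250-fold higher number from compound 1 to compound 2 (2.39 log units; beyond the scatter) is therefore the one measured change, and it concerns the halogenated carbon, not the amine.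

Compound 3 `CN1CCN(c2ccc(S(=O)(=O)C(Cl)(Cl)Br)cc2[N+](=O)[O-])CC1` keeps that halogenated carbon and changes the amine instead: 4-methylpiperazin-1-yl in place of cyclohexylamino on an aromatic carbon. For the measured compounds named here, no measured step touches this position, so nothing here points to a shift beyond the scatter in either direction, and the expectation is a step of a 1.3-fold higher number from compound 1 to compound 3 (0.10 log units; within the scatter) with wide uncertainty. Compound 3 is expected to give about 5000 nM in this assay, most likely between 1200 nM and 40000 nM.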

Compound 3, half-maximal inhibitory concentration: > 1000000 nM
Compound 3: only a limit was reported; the forecaster's own chance of this, stated with the estimate: 10%; middle value at least 200-fold (2.30 log units) away from the limit.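

Among these compounds, replacing cyclohexylamino with 4-methylpiperazin-1-yl on the aromatic carbon gives an at least 250-fold higher number from compound 1 to compound 3 (2.39 log units; beyond the scatter) in this assay, so the amine position, which no earlier step touched, also matters to the reading, and not only the halogenated carbon. The swap changes more than one feature at once, with the ring now holding 2 hetero atoms and the hydrogen-bond donors going from 1 to 0, and this single step cannot separate these differences. The reading of compound 3 is a limit and not a number: the limit of > 1000000 nM in this assay, at which 2 of the 3 values shown sit.

From the compounds shown here alone, it remains open whether piperidin-1-yl, which keeps the ring but has no second ring nitrogen, or morpholin-4-yl would stay measurable in this assay. The same holds for an open-chain amine such as butylamino, which would keep the amine hydrogen without the cyclohexyl ring.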